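Swapping a methyl for a thiadiazole on the amide nitrogen

The source may hold more compounds than are shown below. What is called first, only, known or untested is meant among the compounds shown, and "the series" means these compounds.

Measured compounds:
- compound 1, `CNC(=O)[C@H](c1ccc(Cl)cc1)C(C)C`: 11000 nM
- compound 2, `CC(C)C(C(=O)Nc1ncccn1)c1ccc(Cl)cc1`: 53000 nM
- compound 3, `CC(C)C(C(=O)Nc1cnccn1)c1ccc(Cl)cc1`: 5700 nM

All three share one core and differ only in the group on the amide nitrogen. In a functional assay on CHO cells for agonist activity at Free fatty acid receptor 2 (Homo sapiens), read by cAMP accumulation (a lower number here means a stronger inhibitor, a higher number a weaker inhibitor), compound 1 gives 11000 nM, the second highest of the three numbers. Compound 3 lies close to it, within the scatter, while compound 2 sits clearly higher, beyond the scatter.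

Among the measured compounds shown here, the one counted step, a 9.3-fold lower number from compound 2 to compound 3 (0.97 log units; beyond the scatter), compares two six-membered aromatic rings on that nitrogen and shows that the choice of ring matters a great deal. Compound 4, `CC(C)[C@H](C(=O)Nc1ncns1)c1ccc(Cl)cc1`, is built from compound 1 by the change (1,2,4-thiadiazol-5-yl in place of methyl on an amide-type nitrogen).

For the measured compounds named here, no measured step joins a methyl to a five-membered ring, so the direction of this move is uncertain. Compound 3 shows that an aromatic ring in this position can give a number similar to or a little lower than compound 1, whereas compound 2 shows it can also give a far higher one. Taking the middle ground, compound 4 is expected to land near compound 1, with a step of a 1.8-fold lower number from compound 1 to compound 4 (0.26 log units; within the scatter), giving an estimated 6000 nM within a range from 1000 nM to 40000 nM.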

Compound 4, half-maximal inhibitory concentration: 2000 nM
Estimate against measurement, compound 4: 3.0-fold (0.48 log units) above; the measured number falls inside the stated range.
By their numbers in this assay, from the lowest: compound 4; then compounds 3 and 1 (each within the scatter of the next); then compound 2.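

In this assay, among the compounds shown here, the change from methyl to 1,2,4-thiadiazol-5-yl on the amide-type nitrogen gives a 5.5-fold lower number from compound 1 to compound 4 (0.74 log units; beyond the scatter) and so supplies the first step in this set where a ring at this place lowers the number beyond the scatter, which compound 3 could not show because its number lies within the scatter of the number for compound 1. A ring here does not lower the number on its own, though: compound 2 goes against any such rule, with 53000 nM as its value. Read side by side, compound 2 at 53000 nM and compound 3 at 5700 nM and compound 4 at 2000 nM show that the identity of the ring decides the outcome, and the five-membered ring of compound 4 gives the lowest of the four numbers.

No evidence is available on why this ring lowers the number. As far as these compounds go, it remains open whether a thiazol-2-yl or a phenyl on the same nitrogen would land nearer compound 4 or nearer compound 2, and what a longer chain such as ethyl in place of methyl would give.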